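The source may report more compounds than this note shows. Statements on the series, on what has been measured and on what is new or still open speak of the compounds shown alone.

Measured so far in a functional assay on HO8910 cells (Homo sapiens) for inhibition, read by MTT assay, with a stated time of 24 h, tested at 10 ug/mL; on this read-out lower numbers stand for less inhibition of growth and higher numbers for more inhibition of growth at the one concentration tested:

- Compound 1 `O=C(O)CCCCC(CCSC(=O)c1ccccc1)SC(=O)c1ccccc1` gives "not active" (no number reported)
- Compound 2 `O=C(CCCCC(S)CCS)Nc1ccccc1` gives 5.49%
- Compound 3 `O=C(CCCCC(S)CCS)Nc1ccc(F)cc1` gives 6.81%

Compound 3 at 6.81% and compound 2 at 5.49% lie within the scatter of each other, and both sit low on the read-out. Compound 1 has no number to set beside them.

Compound 4 `O=C(CCCCC(S)CCS)Nc1ccc([N+](=O)[O-])cc1` is still to be measured. Compared with compound 3, it has nitro in place of fluoro on an aromatic carbon, para to a large group (nitro in place of fluoro on an aromatic carbon).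

Among the compounds with values here, the only measured step at this aromatic carbon is a number 1.3 percentage points higher from compound 2 to compound 3 (within the scatter), with fluoro in place of hydrogen. Within the data shown here, that is a single pair, and no compound with nitro has a measured value yet. Taking compound 3 at 6.81% as the starting point, with that one step as the only guide, no step beyond the scatter is expected in this assay, and no direction can be called with any confidence. The expected change is a number 0.2 percentage points higher from compound 3 to compound 4 (within the scatter). For compound 4 the estimated value is 7%, with an expected range from 2% to 18%.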

Compound 4, percent growth inhibition at one concentration: 8.96%
The estimate for compound 4 lay 2 percentage points below the measured number; measured number inside the range.
By their numbers in this assay, from the lowest: compounds 2, 3 and 4 (each within the scatter of the next).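

Nitro in place of fluoro on this aromatic carbon, para to a large group, gives a number 2.2 percentage points higher from compound 3 to compound 4 (within the scatter) in this assay, and nitro in place of hydrogen gives a number 3.5 percentage points higher from compound 2 to compound 4 (within the scatter) on the same read-out. The position has now carried hydrogen, fluoro and nitro, and none of the steps among compounds 2, 3 and 4 leaves the scatter, so these three compounds cannot be ordered. Even the exchange of a single fluorine atom for a nitro group, with three heavy atoms and two hydrogen-bond acceptors, leaves the read-out where it was, and no measurement on hand bears on what lies behind this.

As far as these compounds go, whether an amine or a methoxy group on this aromatic carbon would give a step beyond the scatter remains open, as does whether a substituent elsewhere on the ring would do so. The series also leaves open whether the anilide can be exchanged for another group, since compound 1 differs from compounds 2, 3 and 4 in more than one place and cannot be compared with them.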